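The compounds below may be only part of what the source reports. "The series", "measured", "known", "first", "only" and "open" are said of these compounds alone.

Compound 1 `Cc1cc(C#N)cc(C)c1Oc1nc(Nc2ccc(C#N)cc2)ncc1/C=C/C(=O)NCCOCCO` gives > 200 nM in an ADME assay on TZM cells (Homo sapiens) for cytotoxicity, with a stated time of 1 days (on this read-out lower numbers stand for higher toxicity in this test and higher numbers for lower toxicity in this test), a limit of the assay.
Compound 2 `Cc1cc(C#N)cc(C)c1Oc1nc(Nc2ccc(C#N)cc2)ncc1/C=C/C(=O)N1CCN(S(C)(=O)=O)CC1` gives > 179 nM in this assay, likewise a limit.

From compound 1 to compound 2 the step is a step that the two limits leave unreadable from compound 1 to compound 2, so compound 2 stands only at a limit, one of two such limits shown (the limit of > 179 nM in this assay, at which 1 of the 2 values shown sits). Compound 3 `Cc1cc(C#N)cc(C)c1Oc1nc(Nc2ccc(C#N)cc2)ncc1/C=C/C(=O)N1CCN(C(=O)C(F)(F)F)CC1` differs from compound 2 by (trifluoromethyl)carbonyl in place of methylsulfonyl on an amine nitrogen in a ring. Among the compounds with values here, the one measured step bears on this change only in that neither of its ends was read as a number; the change to compound 3 is therefore expected to leave the read-out at a limit again, a step that the limit leaves unreadable from compound 2 to compound 3 of no readable size. Compound 3 is estimated at 200 nM, between 100 nM and 400 nM.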

Compound 3, half-maximal cytotoxic concentration: > 174 nM
Compound 3: no number, only a limit; the forecaster's own chance of this, stated with the estimate: 80%; the middle value lies beyond the limit too.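

Within the data shown here, compound 1, compound 2 and compound 3 all stand at limits, so no step among them can be read. The compounds shown leave open where any of them lies in this assay, and whether either change shifts the read-out at all.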